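This account rests on a few compounds, and the source may have more. Where it says the series, first, only, none or still open, it means among the compounds named here.

Working notes on the series.

Of the compounds shown here, three carry a measured number so far. Compound 1 `CC(C)(C)c1ccc(C(=O)Nc2ccc(-c3ncccc3C(F)(F)F)cc2)cc1` gives 470 nM in a functional assay on CHO cells for antagonist activity at transient receptor potential cation channel subfamily V member 1 (Homo sapiens), read by FLIPR; a higher number here means a weaker inhibitor, a lower number a stronger inhibitor. Compound 2 `FC(F)(F)c1ccc(-c2nc3cc(-c4ncccc4C(F)(F)F)ccc3[nH]2)cc1` gives 22 nM in this assay, and compound 3 `CC(C)(C)c1ccc(-c2nc3cc(-c4ncccc4C(F)(F)F)ccc3[nH]2)cc1` gives 224 nM in this assay. Compound 3 thus stands second highest of the three numbers; compound 1 sits nearest to it, with a somewhat higher number, while compound 2 lies furthest, with a markedly lower one. Within the data shown here, the single step with the shared core of compounds 2 and 3 is a 10-fold higher number from compound 2 to compound 3 (1.01 log units; beyond the scatter), a large step.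

Compound 4 `Cc1ccc(-c2nc3cc(-c4ncccc4C(F)(F)F)ccc3[nH]2)cc1` is the next member. The change from compound 3 is methyl in place of tert-butyl on an aromatic carbon. Among the measured compounds shown here, no measured step covers a tert-butyl to methyl exchange, so the one step at this position, a 10-fold higher number from compound 2 to compound 3 (1.01 log units; beyond the scatter), bears on it only loosely: it shows that the group at this place can move the number strongly, but in which direction for methyl is open. The expected step is therefore a 1.4-fold higher number from compound 3 to compound 4 (0.15 log units; within the scatter), a modest move upward at most, within a wide range. Compound 4 is estimated at 320 nM in this assay, between 100 nM and 1000 nM.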

Compound 4, half-maximal inhibitory concentration: 170 nM
Compound 4: middle estimate off by 1.9-fold (0.27 log units), on the high side; low and high end bracket the measured number.
By their numbers in this assay, from the lowest: compound 2; then compounds 4 and 3 (each within the scatter of the next); then compound 1.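

In this assay, methyl in place of tert-butyl on an aromatic carbon gives a 1.3-fold lower number from compound 3 to compound 4 (0.12 log units; within the scatter) and thus leaves the number within the scatter, although the group goes from 4 heavy atoms to 1 heavy atom. Methyl in place of trifluoromethyl gives a 7.7-fold higher number from compound 2 to compound 4 (0.89 log units; beyond the scatter) as its step, so among the three groups at this place, trifluoromethyl alone stands apart, while tert-butyl and methyl cannot be told apart. Nothing at hand offers an explanation for this pattern.

The compounds shown leave open how other groups at this place, such as chlorine, a methoxy group, a nitrile or an amine, compare with trifluoromethyl. They also leave open whether trifluoromethyl in place of tert-butyl on the core of compound 1 would bring a step of similar size.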